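The source may hold more compounds than are shown below. What is called first, only, known or untested is meant among the compounds shown, and "the series" means these compounds.

compound 1 `CN(C)c1ccc(/C=C/C(=O)/C=C(O)/C=C/c2ccc(N(C)C)cc2)cc1` gives 78.5 ug/mL
compound 2 `COc1ccccc1NC/C(C(=O)/C=C/c1ccc(N(C)C)cc1)=C(O)\C=C\c1ccc(N(C)C)cc1` gives 76.3 ug/mL
compound 3 `COc1ccc(-n2nc(/C=C/c3ccc(N(C)C)cc3)cc2/C=C/c2ccc(N(C)C)cc2)cc1` gives 88.1 ug/mL

In a physicochemical assay, read by spectrophotometry (on this read-out lower numbers stand for stronger inhibition and higher numbers for weaker inhibition), compound 3 gives 88.1 ug/mL and stands level with the others, as all three numbers lie within the usual scatter of one another. Compound 4 `CN(C)c1ccc(/C=C/c2cc(/C=C/c3ccc(N(C)C)cc3)n(-c3ccccc3)n2)cc1` differs from compound 3 in one place (hydrogen in place of methoxy on an aromatic carbon), with hydrogen in place of methoxy on an aromatic carbon, para to a large group. For the measured compounds named here, no measured pair shows this change alone. Still, compound 1 at 78.5 ug/mL and compound 2 at 76.3 ug/mL stay within the scatter of compound 3 despite larger structural differences. No shift beyond the scatter, in either direction, is therefore expected in this assay here. The expected step (a 1.0-fold lower number from compound 3 to compound 4 (0.02 log units; within the scatter)) is small. For compound 4 the estimated value is 85 ug/mL with an expected range from 55 ug/mL to 125 ug/mL before any measurement.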

Compound 4, half-maximal inhibitory concentration: 74 ug/mL
Beside the measured number, compound 4's estimate is 1.1-fold (0.06 log units) above it; measured number inside the range.
By their numbers in this assay, from the lowest: compounds 4, 2, 1 and 3 (each within the scatter of the next).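

Swapping the methoxy on the aromatic carbon for hydrogen, which turns 4-methoxyphenyl into phenyl, gives a 1.2-fold lower number from compound 3 to compound 4 (0.08 log units; within the scatter) in this assay and offers the first comparison of compounds that differ in one place. In this pair, the methoxy can therefore be removed from this position with no shift beyond the scatter. Nothing available explains this result. Going by these compounds, whether an amine, a carboxylic acid or a longer chain at this position would stay within the scatter remains open, and this single pair cannot show whether the same holds on another core.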